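The compounds below may be only part of what the source reports. "The series", "measured", "known", "first", "only" and "open" are said of these compounds alone.

Compound 2 `Cc1ccccc1CSc1nnc(-c2ccc3c(c2)OCCO3)n1-c1ccccc1` stands at the highest of the two numbers measured in a functional assay on HeLa cells (Homo sapiens) for antiproliferative activity, read by MTT assay, with a stated time of 24 h; on this read-out higher numbers stand for weaker inhibition and lower numbers for stronger inhibition; in this assay compound 2 gives 36000 nM. Going by the values given here, its only measured neighbour is compound 1 `Clc1cccc(CSc2nnc(-c3ccc4c(c3)OCCO4)n2-c2ccccc2)c1`, which in this assay gives 15000 nM, and a 2.4-fold higher number from compound 1 to compound 2 (0.38 log units; beyond the scatter) is the only measured step in this set. Compound 3 `Fc1ccc(CSc2nnc(-c3ccc4c(c3)OCCO4)n2-c2ccccc2)c(F)c1` is unmeasured and differs from compound 2 in one place: 2,4-difluorophenyl in place of 2-methylphenyl on a saturated chain carbon bound to a sulfur. Among the compounds with values here, the measured step bears on this change: it too exchanges one substituted phenyl for another on the same saturated chain carbon bound to a sulfur, and because a 2.4-fold higher number from compound 1 to compound 2 (0.38 log units; beyond the scatter) showed that 2-methylphenyl in place of 3-chlorophenyl raised the number modestly, replacing 2-methylphenyl with 2,4-difluorophenyl is expected to lower it by a comparable modest amount, as a 1.8-fold lower number from compound 2 to compound 3 (0.26 log units; within the scatter), although no measured step involves fluorine. Compound 3 is therefore estimated to give 20000 nM in this assay, within a range from 8000 nM to 60000 nM.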

Compound 3, half-maximal inhibitory concentration: 18600 nM
Compound 3: the middle estimate sits 1.1-fold (0.03 log units) above what was measured; low and high end bracket the measured number.
By their numbers in this assay, from the lowest: compounds 1, 3 and 2 (each within the scatter of the next, the first and the last beyond it).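

In this assay, the new group gives a 1.9-fold lower number from compound 2 to compound 3 (0.29 log units; within the scatter) and, set against the other measured group, a 1.2-fold higher number from compound 1 to compound 3 (0.09 log units; within the scatter). On a saturated chain carbon bound to a sulfur, 2,4-difluorophenyl therefore cannot be told apart from either 2-methylphenyl or 3-chlorophenyl, although those two are separated by a 2.4-fold higher number from compound 1 to compound 2 (0.38 log units; beyond the scatter), so the three compounds form a graded set whose only readable gap lies at its two ends. Nothing shown explains these numbers.

The compounds shown leave open whether any group other than a substituted phenyl at this place, such as an amine, a carboxylic acid or a longer chain, would move the number further. As far as these compounds go, all three also keep the rest of the structure unchanged, so that part remains untested here.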